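The source may hold more compounds than are shown below. What is called first, only, known or untested is meant among the compounds shown, and "the series" means these compounds.

Compound 1 `Cc1cc(Cl)ccc1CC(C)C(=O)N1CCN(c2ccc(C(F)(F)F)cc2[C@@H](N)CC(C)C)CC1`: 38 nM
Compound 2 `CC(C)C[C@H](N)c1cc(C(F)(F)F)ccc1N1CCN(C(=O)CC(C)C(=O)c2ccc(Cl)cc2)CC1`: 1100 nM
Compound 3 `Cc1ccc(OCC(=O)N2CCN(c3ccc(C(F)(F)F)cc3[C@@H](N)CC(C)C)CC2)cc1`: 4400 nM

In an assay on HEK293 cells for displacement of a labelled ligand from Melanocortin receptor 4 (Homo sapiens) (a lower number here means a stronger inhibitor, a higher number a weaker inhibitor), compound 1 gives the lowest number of the three. The step from compound 1 to compound 2 showed a 29-fold higher number from compound 1 to compound 2 (1.46 log units; beyond the scatter), and that from compound 1 to compound 3 showed a 120-fold higher number from compound 1 to compound 3 (2.06 log units; beyond the scatter). Compound 4 `CC(C)C[C@H](N)c1cc(C(F)(F)F)ccc1N1CCN(C(=O)CCC(=O)c2ccc(Cl)cc2)CC1` carries 2-((4-chlorophenyl)carbonyl)ethyl in place of 1-(4-chloro-2-methylbenzyl)ethyl on a carbonyl carbon. Among the compounds with values here, this change most resembles the one in compound 2, which differs from compound 4 only by a methyl on the chain, so the large step of a 29-fold higher number from compound 1 to compound 2 (1.46 log units; beyond the scatter) is the one that bears on it. A step of similar size is therefore expected, a 32-fold higher number from compound 1 to compound 4 (1.50 log units; beyond the scatter). Compound 4 is estimated at 1200 nM, with a range from 300 nM to 5000 nM.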

Compound 4, inhibition constant: 820 nM
Beside the measured number, compound 4's estimate is 1.5-fold (0.17 log units) above it, and the stated range covers the measured number.
By their numbers in this assay, from the lowest: compound 1; then compounds 4 and 2 (each within the scatter of the next); then compound 3.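

With hydrogen in place of methyl on the chain, the change is small, a 1.3-fold lower number from compound 2 to compound 4 (0.13 log units; within the scatter), so this methyl does not separate compound 2 from compound 4. The gap to the 1-(4-chloro-2-methylbenzyl)ethyl group persists without it, a 22-fold higher number from compound 1 to compound 4 (1.33 log units; beyond the scatter), while the carbonyl chain still gives a lower number than the 4-methylphenoxy group, a 5.4-fold lower number from compound 3 to compound 4 (0.73 log units; beyond the scatter). No measurement at hand accounts for these steps.

The compounds shown do not separate the part played by the chain carbonyl from that of the ring methyl in compound 1. On these data alone, whether a hydroxyl in place of that carbonyl, or a longer chain, would narrow the gap remains open.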